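Swapping an Aryl Amide for a Benzyl Amide

A few compounds are considered here, and "the series" means these few. Any claim that something is new, unique, unknown or untested is made for them only; others in the source may bear on it.

Compound 1 `COc1ccc(NC(=O)c2cccc(/C=C3\CC(=O)N(c4ccccc4)C3=O)c2)c(C)c1` was tested in an ADME assay on NCM460 cells (Homo sapiens) for cytotoxicity, read by MTT assay, with a stated time of 72 h; on this read-out lower numbers stand for stronger inhibition and higher numbers for weaker inhibition. In this assay compound 1 gave only a limit, > 100000 nM, not a number. Compound 2 `CCCCCN1C(=O)C/C(=C\c2cccc(C(=O)Nc3ccc(OC)cc3)c2)C1=O` in this assay also gave only a limit, > 100000 nM. Compound 3 `CCCCNC(=O)c1cccc(/C=C2\CC(=O)N(Cc3ccccc3)C2=O)c1` in this assay likewise gave only a limit, > 100000 nM. Within the data shown here, compound 1 therefore stands together with the others at the limit of > 100000 nM in this assay, at which 3 of the 3 values shown sit, and no measured compound shows a true number. Compound 4 `O=C(NCc1ccccc1)c1cccc(/C=C2\CC(=O)N(c3ccccc3)C2=O)c1` has not yet been measured; it differs from compound 1 in one place: benzyl in place of 4-methoxy-2-methylphenyl on an amide-type nitrogen. Among the measured compounds shown here, because every measured value sits at the limit of > 100000 nM in this assay, at which 3 of the 3 values shown sit, no step between two numbers exists to guide the expectation. The step of a number no higher from compound 1 to compound 4 (the limit leaves the size open) is expected to be none beyond the scatter. Compound 4 is expected to give 100000 nM, within 50000 nM to 200000 nM, most likely again reported only as a limit.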

Compound 4, half-maximal inhibitory concentration: > 100000 nM
Compound 4 was reported as a limit (the forecaster's own chance of this, stated with the estimate: 85%); the middle value lies on the limit itself.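

Among these compounds, compound 1 and compound 4 each gave only a limit in this assay, so no step between them can be read: the limit of > 100000 nM in this assay, at which 4 of the 4 values shown sit. The compounds shown leave open whether benzyl in place of 4-methoxy-2-methylphenyl changes cytotoxicity at all.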